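Nitro for trifluoromethyl on the carbonyl-bound arene: compound 4

The source may report more compounds than this note shows. Statements on the series, on what has been measured and on what is new or still open speak of the compounds shown alone.

Compound 3 `CN(C(=O)NC(=O)c1ccc(C(F)(F)F)cc1)c1nc(C(F)(F)F)c(C(=O)N/N=C/c2cccc(C(F)(F)F)c2)s1` stands at the lowest number of the three measured in a functional assay on BCG823 cells (Homo sapiens) for inhibition, read by MTT assay, with a stated time of 72 h (on this read-out lower numbers stand for stronger inhibition and higher numbers for weaker inhibition), giving 1.84 ug/mL. Compound 2 `CN(C(=O)NC(=O)c1ccc([N+](=O)[O-])cc1)c1nc(C(F)(F)F)c(C(=O)N/N=C/c2ccc([N+](=O)[O-])cc2)s1` gives 7.45 ug/mL, and compound 1 `CN(C(=O)NC(=O)c1c(F)cccc1F)c1nc(C(F)(F)F)c(C(=O)N/N=C/c2cccc(C(F)(F)F)c2)s1` gives 25.9 ug/mL. Going by the values given here, the only single-point step measured so far, a 14-fold lower number from compound 1 to compound 3 (1.15 log units; beyond the scatter), concerns the same carbonyl-bound aryl and was large, which shows that this part of the molecule can move the read-out a long way. Compound 4 `CN(C(=O)NC(=O)c1ccc([N+](=O)[O-])cc1)c1nc(C(F)(F)F)c(C(=O)N/N=C/c2cccc(C(F)(F)F)c2)s1` differs from compound 3 only by nitro in place of trifluoromethyl on an aromatic carbon. Among the compounds with values here, no measured step isolates this exchange. Compound 2 carries nitro on both arenes and its value of 7.45 ug/mL lies above that of compound 3, but two positions differ there, so it bears on the present step only loosely. A moderate rise in number is expected, smaller than the gap between compound 3 and compound 2: only one of the two positions that differ there is changed in compound 4. The expected step is a 2.2-fold higher number from compound 3 to compound 4 (0.34 log units; beyond the scatter). Compound 4 is therefore estimated at 4 ug/mL, with a range from 1.5 ug/mL to 12 ug/mL.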

Compound 4, half-maximal inhibitory concentration: 1.67 ug/mL
Compound 4: middle estimate off by 2.4-fold (0.38 log units), on the high side; the measured number falls inside the stated range.
By their numbers in this assay, from the lowest: compounds 4 and 3 (each within the scatter of the next); then compound 2; then compound 1.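

On the carbonyl-bound arene in this assay, the exchange of 4-(trifluoromethyl)phenyl for 4-nitrophenyl gives a 1.1-fold lower number from compound 3 to compound 4 (0.04 log units; within the scatter) and so does not separate the two groups at this position. The large step away from 2,6-difluorophenyl also holds with 4-nitrophenyl, at a 16-fold lower number from compound 1 to compound 4 (1.19 log units; beyond the scatter), so it does not depend on trifluoromethyl alone. With the carbonyl-bound 4-nitrophenyl held constant, 3-(trifluoromethyl)phenyl in place of 4-nitrophenyl on the carbon with a double bond to nitrogen gives a 4.5-fold lower number from compound 2 to compound 4 (0.65 log units; beyond the scatter) and shows that this other arene also moves the read-out.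

No measurement at hand accounts for the match between nitro and trifluoromethyl. From the compounds shown here alone, whether an amine, a carboxylic acid or a plain hydrogen on the same aromatic carbon would keep the number this low remains open.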